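The source may report more compounds than this note shows. Statements on the series, on what has been measured and on what is new or still open speak of the compounds shown alone.

Of the compounds shown here, three sharing one core have been measured in a functional assay on HT-29 cells (Homo sapiens) for cytotoxicity, read by MTT assay, with a stated time of 24 h, tested at 80 ug/mL; a lower number here means a weaker effect, a higher number a stronger effect of the compound at the concentration tested. Compound 1 `Cn1c(-c2ccc(NC(=O)CCl)cc2)nc(-c2ccccc2)c1-c1ccccc1` gives 76.1%, compound 2 `Cn1cnnc1SCC(=O)Nc1ccc(-c2nc(-c3ccccc3)c(-c3ccccc3)n2C)cc1` gives 88%, and compound 3 `CN1CCN(CC(=O)Nc2ccc(-c3nc(-c4ccccc4)c(-c4ccccc4)n3C)cc2)CC1` gives 53.1%, the lowest of the three numbers. The two steps that reach compound 3 both change the group on a saturated chain carbon bound to a carbonyl carbon: a number 23 percentage points lower from compound 1 to compound 3 (beyond the scatter) and a number 34.9 percentage points lower from compound 2 to compound 3 (beyond the scatter).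

Compound 4 `COc1ccc(CN2CCN(CC(=O)Nc3ccc(-c4nc(-c5ccccc5)c(-c5ccccc5)n4C)cc3)CC2)cc1` is the next step. It differs from compound 3 in one place: 4-methoxyphenyl in place of hydrogen on a saturated chain carbon bound to an amine nitrogen in a ring. This change sits at a different place from the two measured steps, on a saturated chain carbon bound to an amine nitrogen in a ring, so neither measured step bears on it directly; they only show that changes to the chain on this core move the number by modest to large amounts. Within the data shown here, with no measured step at this place, the expected change is small: a number 4.9 percentage points higher from compound 3 to compound 4 (within the scatter). The estimate for compound 4 is 58%, with a range from 40% to 78%.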

Compound 4, a percentage reported as activity, at one concentration (the size of the read-out at that concentration, not a potency): 51.2%
Compound 4: middle estimate off by 6.8 percentage points, on the high side; the measured number falls inside the stated range.
By their numbers in this assay, from the lowest: compounds 4 and 3 (each within the scatter of the next); then compound 1; then compound 2.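

The change at this place is sizeable, since it brings in 4-methoxyphenyl with its 8 heavy atoms and aromatic ring, turning methyl into 4-methoxybenzyl, yet it gives a number 1.9 percentage points lower from compound 3 to compound 4 (within the scatter) in this assay. Unlike the two earlier steps, which replaced the whole group on the saturated chain carbon bound to a carbonyl carbon, this one shows that a large addition further out on the 4-methylpiperazin-1-yl group need not produce a difference that can be told from scatter. Nothing available here bears on the reason for this result.

On these data alone, whether a carboxylic acid, an amine or a longer chain at this same place would give a different number remains open. One added group cannot show how this place responds in general, and a reading at a single concentration does not give potency.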